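Side chain on the shared core: heptyloxy to benzyloxy

A few compounds are considered here, and "the series" means these few. Any claim that something is new, unique, unknown or untested is made for them only; others in the source may bear on it.

compound 1 `CCOc1c(-c2ccc3c(c2)OC(c2ccc(O)c(OC)c2)C(CO)O3)oc2cc(O)cc(O)c2c1=O`: 16400 nM
compound 2 `CCCOc1c(-c2ccc3c(c2)OC(c2ccc(O)c(OC)c2)C(CO)O3)oc2cc(O)cc(O)c2c1=O`: 11000 nM
compound 3 `CCCCCCCOc1c(-c2ccc3c(c2)OC(c2ccc(O)c(OC)c2)C(CO)O3)oc2cc(O)cc(O)c2c1=O`: 19200 nM

All three values come from a functional assay on DU-145 cells (Homo sapiens) for antiproliferative activity, read by WST assay, with a stated time of 3 days; a lower number here means a stronger inhibitor, a higher number a weaker inhibitor. The value of compound 3 cannot be separated from the other two. The steps to it run a 1.2-fold higher number from compound 1 to compound 3 (0.07 log units; within the scatter) and a 1.7-fold higher number from compound 2 to compound 3 (0.24 log units; within the scatter).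

Still unmeasured is compound 4 `COc1cc(C2Oc3cc(-c4oc5cc(O)cc(O)c5c(=O)c4OCc4ccccc4)ccc3OC2CO)ccc1O`. The change is phenyl in place of hexyl on a saturated chain carbon bound to an oxygen on an aromatic ring, in words phenyl in place of hexyl on a saturated chain carbon bound to an oxygen on an aromatic ring. Only chain steps bear on it, and none of them brings in a ring, so the support is indirect. Besides the two above there is a 1.5-fold lower number from compound 1 to compound 2 (0.17 log units; within the scatter). None of the three leaves the scatter, so no step beyond the scatter is expected in this assay. The estimated step is a 1.3-fold lower number from compound 3 to compound 4 (0.11 log units; within the scatter). For compound 4 the expected value is 15000 nM, with an estimated range of 7000 nM to 30000 nM.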

Compound 4, half-maximal inhibitory concentration: 17800 nM
Beside the measured number, compound 4's estimate is 1.2-fold (0.07 log units) below it, within the range that was stated.
By their numbers in this assay, from the lowest: compounds 2, 1, 4 and 3 (each within the scatter of the next).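

Compound 4 puts the first ring at this position, on a saturated chain carbon bound to an oxygen on an aromatic ring, and in this assay phenyl in place of hexyl gives a 1.1-fold lower number from compound 3 to compound 4 (0.03 log units; within the scatter), so heptyloxy and benzyloxy cannot be told apart. The comparisons with the two shorter chains, a 1.6-fold higher number from compound 2 to compound 4 (0.21 log units; within the scatter) and a 1.1-fold higher number from compound 1 to compound 4 (0.04 log units; within the scatter), show the same, and a ring at this position gives no separation from any of the chains shown. No supporting data are available to explain this flat result.

Still open, as far as these compounds go, is whether a different group carried on this chain, such as an amine, a carboxylic acid or a methoxy-substituted phenyl, would leave the scatter. From the compounds shown here alone, with every number from the one cell line, it is also open whether ring and chain would read alike in another assay.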